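This account rests on a few compounds, and the source may have more. Where it says the series, first, only, none or still open, it means among the compounds named here.

Compound 1, `Nc1nc(OCC(F)(F)F)c2ncn(/C=C3/CC3(CO)CO)c2n1`: in an ADME assay on Akata cells (Homo sapiens) for cytotoxicity, with a stated time of 7 days (on this read-out lower numbers stand for higher toxicity in this test and higher numbers for lower toxicity in this test), compound 1 gives > 20000 nM, which is a limit of the assay and not a number.
Compound 2, `C=CCOc1nc(N)nc2c1ncn2/C=C1/CC1(CO)CO`: in this assay compound 2 gives > 20000 nM, again a limit of the assay.
Compound 3, `CCCCCCCCSc1nc(N)nc2c1ncn2/C=C1/CC1(CO)CO`: in this assay compound 3 gives > 20000 nM, also a limit of the assay.

Compound 3 therefore stands at the limit of this assay, and every value seen so far sits at the same limit (the limit of > 20000 nM in this assay, at which 3 of the 3 values shown sit). Compound 4, `CCCCNc1nc(N)nc2c1ncn2/C=C1/CC1(CO)CO`, has not yet been measured. It differs from compound 3 in one place: butylamino in place of octylsulfanyl on an aromatic carbon. The three measured steps all change the group bound to an aromatic carbon of the shared core or a chain on it, and none of them can be read, because all values are limits: a step that the two limits leave unreadable from compound 1 to compound 3, a step that the two limits leave unreadable from compound 2 to compound 3 and a step that the two limits leave unreadable from compound 1 to compound 2. For the measured compounds named here, no measured step therefore gives a size or a direction for the new change. The expected step that the limit leaves unreadable from compound 3 to compound 4 is one that cannot be told apart from the scatter, and most likely compound 4 will also give only a limit. The estimate for compound 4 in this assay is 30000 nM, with a range from 12000 nM to 100000 nM.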

Compound 4, half-maximal cytotoxic concentration: > 24000 nM
Compound 4: no number, only a limit (the forecaster's own chance of this, stated with the estimate: 85%); the middle value is on the limit's open side.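

In this assay compound 4 gives > 24000 nM, which is a limit of the assay and not a number. Compound 1, compound 2 and compound 3 also give only limits, so none of their steps to compound 4 can be read. As far as these compounds go, whether changing the group on the aromatic carbon alters the half-maximal cytotoxic concentration, and by how much, stays open.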